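A Urea Arm Replaces a Phenethyl Chain

The source may report more compounds than this note shows. Statements on the series, on what has been measured and on what is new or still open speak of the compounds shown alone.

Of the compounds shown here, two built on one shared core have been measured in an assay on LtK cells with ATP-sensitive inward rectifier potassium channel 11 (Homo sapiens) as the target; a higher number here means that more compound is needed for the effect, a lower number that less compound is needed. Compound 1 `C/C=C/C(=O)Nc1c(C(O)(C(F)(F)F)C(F)(F)F)ccc2ccccc12` carries a prop-1-en-1-yl group on the carbonyl carbon and in this assay gives 72 nM. Compound 2 `O=C(CCc1ccccc1)Nc1c(C(O)(C(F)(F)F)C(F)(F)F)ccc2ccccc12` carries a phenethyl group at that same position and gives 1750 nM. Among the measured compounds shown here, the single step between them, a 24-fold higher number from compound 1 to compound 2 (1.39 log units; beyond the scatter), shows that what hangs on the carbonyl carbon can move the number a long way. For the measured compounds named here, of the two numbers, compound 2 stands at the higher one, with compound 1 as its only neighbour.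

Compound 3 `O=C(Nc1ccc(Cl)cc1)Nc1c(C(O)(C(F)(F)F)C(F)(F)F)ccc2ccccc12` differs from compound 2 in one place: (4-chlorophenyl)amino in place of phenethyl on a carbonyl carbon. Going by the values given here, the amide thereby becomes a urea, a change for which no measured step exists here. Among the compounds with values here, the only step at hand, from compound 1 to compound 2, bears on it merely by showing how large a swing this position allows. The direction cannot be read from the data, so the step of a 2.5-fold lower number from compound 2 to compound 3 (0.40 log units; beyond the scatter) is expected to be modest and very uncertain. Compound 3 is therefore estimated at 700 nM, likely between 120 nM and 4000 nM.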

Compound 3, half-maximal effective concentration: 276 nM
For compound 3 the middle estimate is 2.5-fold (0.40 log units) above the measured one; the measured number falls inside the stated range.
By their numbers in this assay, from the lowest: compound 1; then compound 3; then compound 2.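

In this assay, swapping phenethyl for (4-chlorophenyl)amino gives a 6.3-fold lower number from compound 2 to compound 3 (0.80 log units; beyond the scatter), although both groups hold 8 heavy atoms and one six-membered aromatic ring of carbon only, so matching counts of this kind do not fix the number at this position. The urea arm of compound 3 still does not reach the amide with the prop-1-en-1-yl group, as the step of a 3.8-fold higher number from compound 1 to compound 3 (0.58 log units; beyond the scatter) shows, which leaves compound 1 with the lowest number of the three, and an arm carrying an aromatic ring has so far come with a higher number than prop-1-en-1-yl. No outside measurement is available to explain either step.

The nitrogen and the chlorine enter together in compound 3, and the compounds shown cannot separate what each contributes to the step. A urea with a plain phenyl ring would isolate the chlorine, a phenethyl chain bearing a chlorine would isolate the nitrogen, and a short methylamino arm on the same carbonyl carbon would show whether a urea can come down to the number of compound 1.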